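Three hydroxyphenyl groups on one core: moving a hydroxyl

A few compounds are considered here, and "the series" means these few. Any claim that something is new, unique, unknown or untested is made for them only; others in the source may bear on it.

Compound 1 `Oc1ccc(-c2cc(-c3ccccc3O)cc(-c3ccccc3O)n2)cc1` is one of three measured compounds sharing a core. In an assay on isolated protein for inhibition of DNA topoisomerase 1 (Homo sapiens), with a stated time of 30 min, tested at 100 uM (on this read-out higher numbers stand for more inhibition at the one concentration tested (going by the name of the read-out) and lower numbers for less inhibition), compound 1 gives 0.3%, which places it second highest of the three numbers, with compound 2 nearest and compound 3 furthest. Compound 2 `Oc1ccc(-c2cc(-c3ccc(O)cc3)nc(-c3ccccc3O)c2)cc1` gives 0% in this assay, and the step is a number 0.3 percentage points lower from compound 1 to compound 2 (within the scatter). Compound 3 `Oc1ccc(-c2cc(-c3cccc(O)c3)cc(-c3ccccc3O)n2)cc1` gives 8.4% in this assay, a step of a number 8.1 percentage points higher from compound 1 to compound 3 (within the scatter); between compound 2 and compound 3 the step is a number 8.4 percentage points higher from compound 2 to compound 3 (within the scatter).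

Compound 4 `Oc1ccc(-c2cc(-c3ccccc3O)cc(-c3cccc(O)c3)n2)cc1` has not yet been measured. It differs from compound 1 by 3-hydroxyphenyl in place of 2-hydroxyphenyl on an aromatic carbon. Among the compounds with values here, the steps that bear on this are those into compound 3, where a 3-hydroxyphenyl also enters: a number 8.1 percentage points higher from compound 1 to compound 3 (within the scatter) and a number 8.4 percentage points higher from compound 2 to compound 3 (within the scatter), both within the scatter. On that basis the expected step from compound 1 is a number 3.7 percentage points higher from compound 1 to compound 4 (within the scatter), nothing beyond the scatter. Compound 4 is therefore estimated to give 4% in this assay, with a range from 0% to 13%.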

Compound 4, a percentage reported as inhibition, at one concentration (the size of the read-out at that concentration, not a potency): 0%
The estimate for compound 4 lay 4 percentage points above the measured number; the measured number falls inside the stated range.
By their numbers in this assay, from the lowest: compounds 2, 4, 1 and 3 (each within the scatter of the next).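

In this assay, the exchange of 2-hydroxyphenyl for 3-hydroxyphenyl on the carbon next to the ring nitrogen gives a number 0.3 percentage points lower from compound 1 to compound 4 (within the scatter). Within the data shown here, the earlier steps, including the same exchange in a number 8.1 percentage points higher from compound 1 to compound 3 (within the scatter), changed a different aromatic carbon of the core, so this is the first sign that moving the hydroxyl at this second place also leaves the read-out within the scatter. Nothing given here bears on why the hydroxyl's move has so little effect at this position.

With every step within the scatter, the compounds shown leave open whether any group at this position could shift the read-out beyond it. An amine or a carboxylic acid in place of the hydroxyl, or a longer chain between the hydroxyl and the ring, would test this.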